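A few compounds are considered here, and "the series" means these few. Any claim that something is new, unique, unknown or untested is made for them only; others in the source may bear on it.

Measured so far in a functional assay on HepG2 cells (Homo sapiens) for antiproliferative activity, read by MTT assay, with a stated time of 48 h; a lower number here means a stronger inhibitor, a higher number a weaker inhibitor:
- compound 1 `COc1ccc(/C=C/c2cc(OC)cc(OC)c2/C=C/C(=O)c2ccc(C)cc2)cc1` gives 4.8 ug/mL
- compound 2 `COc1ccc(/C=C/c2cc(OC)cc(OC)c2/C=C/C(=O)c2cccc(Cl)c2)cc1` gives 9.5 ug/mL
- compound 3 `COc1ccc(/C=C/c2cc(OC)cc(OC)c2/C=C/C(=O)c2ccc(N)cc2)cc1` gives 7.5 ug/mL

These three compounds keep a shared core and differ only in the group on the carbonyl carbon: 4-methylphenyl, 3-chlorophenyl or 4-aminophenyl. Compound 3 cannot be told apart from the other two in this assay. The data show a 1.6-fold higher number from compound 1 to compound 3 (0.19 log units; within the scatter) and also a 1.3-fold lower number from compound 2 to compound 3 (0.10 log units; within the scatter), so its value sits among theirs without a real separation.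

The next compound is compound 4 `COc1ccc(/C=C/c2cc(OC)cc(OC)c2/C=C/C(=O)c2ccccc2)cc1`. The change is hydrogen in place of amino on an aromatic carbon, which means hydrogen in place of amino on an aromatic carbon, para to a large group. Among the measured compounds shown here, no measured pair shows this exact swap. The closest evidence is the exchange of amino for methyl at that ring, seen in a 1.6-fold higher number from compound 1 to compound 3 (0.19 log units; within the scatter). The remaining comparison, a 2.0-fold higher number from compound 1 to compound 2 (0.30 log units; within the scatter), also stays inside the scatter, so no change of this group has yet produced a clear shift. No step beyond the scatter is therefore expected, and no direction can be favoured. The estimate amounts to a 1.1-fold lower number from compound 3 to compound 4 (0.03 log units; within the scatter). Compound 4 is expected at 7 ug/mL, with an estimated range from 3.5 ug/mL to 14 ug/mL.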

Compound 4, half-maximal inhibitory concentration: 6.8 ug/mL
Compound 4: middle estimate off by 1.0-fold (0.01 log units), on the high side; the measured number falls inside the stated range.
By their numbers in this assay, from the lowest: compounds 1, 4, 3 and 2 (each within the scatter of the next).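

Among the compounds shown here, compound 4 carries a plain benzoyl group, with only hydrogen on the ring, and this gives the series the unsubstituted comparison that the earlier compounds lacked in this assay so far as the shared core goes. Hydrogen in place of amino gives a 1.1-fold lower number from compound 3 to compound 4 (0.04 log units; within the scatter) while hydrogen in place of chloro gives a 1.4-fold lower number from compound 2 to compound 4 (0.15 log units; within the scatter) and hydrogen in place of methyl gives a 1.4-fold higher number from compound 1 to compound 4 (0.15 log units; within the scatter) in the third comparison. With all three steps inside the scatter, neither amino, methyl nor chloro can be told apart from hydrogen on this ring, so for these compounds the ring needs none of these groups to give a number in this range.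

Still open, from the compounds shown here alone, is whether a group of a different kind in the same place, such as a carboxylic acid, a nitrile or a longer chain like butyl, or a different ring on the carbonyl carbon, would produce a step beyond the scatter. Nothing measured alongside these numbers bears on why the four values lie so close together.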